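A few compounds are considered here, and "the series" means these few. Any claim that something is new, unique, unknown or untested is made for them only; others in the source may bear on it.

Of the compounds shown here, three sharing one core have been measured in a functional assay on MCF7 cells (Homo sapiens) for antiproliferative activity, read by MTT assay, with a stated time of 72 h; on this read-out lower numbers stand for stronger inhibition and higher numbers for weaker inhibition: compound 1 (`O=S(=O)(Oc1ccccc1C(F)(F)F)C1CC2OC1C(c1ccc(/C=C/c3cc(O)cc(O)c3)cc1)=C2c1ccc(O)cc1`) gives 18300 nM, compound 2 (`O=S(=O)(Oc1cccc(C(F)(F)F)c1)C1CC2OC1C(c1ccc(/C=C/c3cc(O)cc(O)c3)cc1)=C2c1ccc(O)cc1`) gives 11500 nM and compound 3 (`O=S(=O)(Oc1ccc(-c2ccccc2)cc1)C1CC2OC1C(c1ccc(/C=C/c3cc(O)cc(O)c3)cc1)=C2c1ccc(O)cc1`) gives 7800 nM. Compound 3 lies clear of compound 1, with a 2.3-fold lower number from compound 1 to compound 3 (0.37 log units; beyond the scatter), but level with compound 2, with a 1.5-fold lower number from compound 2 to compound 3 (0.17 log units; within the scatter). Compound 4 (`O=S(=O)(Oc1ccc(O)cc1)C1CC2OC1C(c1ccc(/C=C/c3cc(O)cc(O)c3)cc1)=C2c1ccc(O)cc1`) carries hydroxy in place of phenyl on an aromatic carbon, para to a large group: hydroxy in place of phenyl on an aromatic carbon. The measured steps at this site are all small, the third being a 1.6-fold lower number from compound 1 to compound 2 (0.20 log units; within the scatter), and none of them swaps phenyl for hydroxy. No change beyond the scatter is therefore expected, and the direction is uncertain. The expected step is a 1.4-fold higher number from compound 3 to compound 4 (0.15 log units; within the scatter). For compound 4 the estimated value is 11000 nM, within a range from 4500 nM to 26000 nM.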

Compound 4, half-maximal inhibitory concentration: 14100 nM
For compound 4 the middle estimate is 1.3-fold (0.11 log units) below the measured one; the range from low to high includes it.
By their numbers in this assay, from the lowest: compounds 3, 2, 4 and 1 (each within the scatter of the next, the first and the last beyond it).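

In this assay, hydroxy in place of phenyl on an aromatic carbon, para to a large group, gives a 1.8-fold higher number from compound 3 to compound 4 (0.26 log units; within the scatter) and so removes an entire aromatic ring without a change beyond the scatter. Set against the two trifluoromethyl-bearing groups, the 4-hydroxyphenyl group gives a 1.2-fold higher number from compound 2 to compound 4 (0.09 log units; within the scatter) and a 1.3-fold lower number from compound 1 to compound 4 (0.11 log units; within the scatter) and thus stands apart from neither. Nothing available explains this result. From the compounds shown here alone, whether an amine, a carboxylic acid or a methoxy group on this carbon would shift the number beyond the scatter remains open.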